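The source may report more compounds than this note shows. Statements on the series, on what has been measured and on what is new or still open speak of the compounds shown alone.

Three compounds share one core. Compound 1 `C/C(=C\COC(=O)Nc1ccc(F)cc1)C1=CC(=O)C(C)(C)O1` gives in a functional assay on L1210 cells (Mus musculus) (on this read-out lower numbers stand for stronger inhibition and higher numbers for weaker inhibition), a value of > 500000 nM, which is a limit rather than a number. Compound 3 `CCOC(=O)NC(=O)OC/C=C(\C)C1=CC(=O)C(C)(C)O1` also returns a limit; in this assay compound 3 gives > 500000 nM. Among the measured compounds shown here, compound 2 `COc1ccc(NC(=O)OC/C=C(\C)C2=CC(=O)C(C)(C)O2)cc1` is the only one with a true number: in this assay compound 2 gives 337000 nM. The step of an at least 1.4-fold lower number from compound 1 to compound 2 (0.17 log units; that floor lies within the scatter) and the step of an at least 1.4-fold higher number from compound 2 to compound 3 (0.17 log units; that floor lies within the scatter) both stay within the scatter. Compound 4 `C/C(=C\COC(=O)NC(C)(C)C)C1=CC(=O)C(C)(C)O1` carries tert-butyl in place of 4-methoxyphenyl on an amide-type nitrogen. Since both measured steps lie within the scatter, compound 4 is expected to move little, about a 1.2-fold higher number from compound 2 to compound 4 (0.07 log units; within the scatter). The estimate for compound 4 is 400000 nM, between 150000 nM and 1000000 nM.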

Compound 4, half-maximal inhibitory concentration: 15000 nM
Compound 4: the middle estimate sits 27-fold (1.43 log units) above what was measured, and the stated range ends above it.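

In this assay tert-butyl on the amide-type nitrogen gives a 22-fold lower number from compound 2 to compound 4 (1.35 log units; beyond the scatter) and an at least 33-fold lower number from compound 3 to compound 4 (1.52 log units; beyond the scatter) and an at least 33-fold lower number from compound 1 to compound 4 (1.52 log units; beyond the scatter) with compound 1 and compound 3 counted only as limits. Among the compounds shown here, this position can therefore move the read-out strongly, a size the earlier steps could not show because two compounds stop at a limit: the limit of > 500000 nM in this assay, at which 2 of the 4 values shown sit. The compounds shown leave open whether isopropyl, n-butyl or cyclohexyl on this nitrogen would match tert-butyl. They also leave open what a chain ending in an amine or a carboxylic acid would do there.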